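Styryl for phenyl on a pyrazoline cytotoxicity series

This account rests on a few compounds, and the source may have more. Where it says the series, first, only, none or still open, it means among the compounds named here.

The study measures cytotoxicity in a functional assay on HEp-2 cells (Homo sapiens) for cytotoxicity, read by sulforhodamine B assay, with a stated time of 48 h; a higher number here means a weaker inhibitor, a lower number a stronger inhibitor. Of the compounds shown here, three have been measured. Compound 1 `CC(=O)N1N=C(c2cccc([N+](=O)[O-])c2)CC1c1ccccc1` gives 8930 nM in this assay. Compound 2 `CC(=O)N1N=C(c2cccc3ccccc23)CC1c1cccc(Cl)c1Cl` gives 16800 nM in this assay. Compound 3 `O=CCN1N=C(c2ccc3ccccc3c2)CC1c1ccccc1` gives 8400 nM in this assay. Compound 3 has the lowest of the three numbers, but its gap to compound 1 and its gap to compound 2 both lie within the usual scatter of this assay, so no order among the three can be claimed.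

Compound 4 `O=CCN1N=C(c2ccc3ccccc3c2)CC1/C=C/c1ccccc1` has not yet been measured. It differs from compound 3 in one place: 2-phenylethenyl in place of phenyl on a saturated ring carbon. Among the measured compounds shown here, no measured pair in the set shows a change of this kind, so there is no earlier step to draw on. Without such a step, the expectation rests on compound 3 alone, whose value of 8400 nM is taken as the anchor. The step expected from this change is a 1.2-fold lower number from compound 3 to compound 4 (0.08 log units; within the scatter), which is not expected to reach beyond the scatter. Compound 4 is therefore estimated at 7000 nM in this assay, with a range from 2500 nM to 20000 nM.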

Compound 4, half-maximal inhibitory concentration: 20100 nM
The estimate for compound 4 lay 2.9-fold (0.46 log units) below the measured number; the measured number lies above the stated range.
By their numbers in this assay, from the lowest: compounds 3, 1, 2 and 4 (each within the scatter of the next, the first and the last beyond it).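

In this assay, among the compounds shown here, this saturated ring carbon, next to the ring nitrogen, proves sensitive to the group it carries: 2-phenylethenyl in place of phenyl gives a 2.4-fold higher number from compound 3 to compound 4 (0.38 log units; beyond the scatter), a modest step but the first single change in the set that can be read. The aromatic ring of carbon is kept in what enters, so the step comes with a longer group holding a double bond outside aromatic rings, and not with the loss of that ring. Nothing available accounts for the weaker result of compound 4.

The compounds shown do not separate the double bond from the added length, which a saturated 2-phenylethyl group at this carbon would address. They also leave open whether a smaller group such as methyl would differ from phenyl here, and whether the step holds on the cores of compound 1 and compound 2.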